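Swapping Bromine for Iodine on Two Calpain Inhibitor Cores

The compounds below may be only part of what the source reports. "The series", "measured", "known", "first", "only" and "open" are said of these compounds alone.

Compound 1 `O=C(O)/C(S)=C/c1c[nH]c2cc(Br)ccc12` and compound 2 `O=C(O)/C(S)=C/c1c[nH]c2cc(I)ccc12` share one core, while compound 3 `O=C(O)/C(S)=C/c1ccccc1Br` is built on another; the difference between the two cores is not broken down here. In an assay on isolated protein for inhibition of Calpain-1 catalytic subunit (Sus scrofa) (a higher number here means a weaker inhibitor, a lower number a stronger inhibitor), compound 1 gives 90 nM, compound 2 gives 300 nM, and compound 3 gives 9100 nM. The change from compound 1 to compound 2 is iodo in place of bromo on an aromatic carbon, and it gave a 3.3-fold higher number from compound 1 to compound 2 (0.52 log units; beyond the scatter). Compound 4 `O=C(O)/C(S)=C/c1ccccc1I` arises from compound 3 by the same kind of change, (iodo in place of bromo on an aromatic carbon); the surroundings differ, since in compound 2 the carbon belongs to a fused system of two rings, meta and para to a fused ring, whereas in compound 4 the ring stands alone and the carbon is ortho to a group of 6 heavy atoms. Resting on a 3.3-fold higher number from compound 1 to compound 2 (0.52 log units; beyond the scatter), the expected step is a 3.3-fold higher number from compound 3 to compound 4 (0.52 log units; beyond the scatter). Compound 4 is therefore estimated at 30000 nM, likely between 12000 nM and 75000 nM.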

Compound 4, half-maximal inhibitory concentration: 42800 nM
Compound 4: middle estimate off by 1.4-fold (0.15 log units), on the low side; measured number inside the range.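

In this assay, iodo in place of bromo on the core of compound 3 gave a 4.7-fold higher number from compound 3 to compound 4 (0.67 log units; beyond the scatter), so the change again made the inhibitor weaker. Set beside the step on the other core, the size of the change carried over: the same change on two cores in this assay, a 3.3-fold higher number (0.52 log units; beyond the scatter) from compound 1 to compound 2 and a 4.7-fold higher number (0.67 log units; beyond the scatter) from compound 3 to compound 4, 1.4-fold (0.15 log units) apart, within the scatter of two such steps. Within the data shown here, this rests on only two pairs, so it shows agreement between these two cores but does not show that the step would hold on any further core, and it does not explain why iodo gives weaker inhibition.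

Still open, going by these compounds, is how chloro, fluoro or an amine on the same aromatic carbon would compare with bromo and iodo. On these data alone, it is also open whether either core would respond to them in the same way.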